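The compounds below may be only part of what the source reports. "The series", "measured", "known", "first", "only" and "open" are said of these compounds alone.

In a functional assay on HT-29 cells (Homo sapiens) for inhibition (on this read-out higher numbers stand for weaker inhibition and lower numbers for stronger inhibition), compound 1 `COc1cccc(/C=C\c2ccc3ccccc3c2)c1` gives 1920 nM. Compound 2 `COc1cc(/C=C/c2ccc(N(C)C)c([N+](=O)[O-])c2)cc(OC)c1OC` gives > 5000 nM, which is a limit of the assay and not a number. Compound 3 `COc1cc(/C=C\c2ccc(N(C)C)c([N+](=O)[O-])c2)cc(OC)c1OC` gives > 5000 nM, and this too is a limit. As far as these compounds go, compound 3 therefore stands at the limit of > 5000 nM in this assay, at which 2 of the 3 values shown sit, and its actual potency in this assay remains unknown. Compound 4 `COc1cc(/C=C\c2ccc(N(C)C)c(N)c2)cc(OC)c1OC` differs from compound 3 in one place, amino in place of nitro on an aromatic carbon, ortho to a dimethylamino group.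

Among the compounds with values here, only one measured step bears on compound 3, namely a step that the two limits leave unreadable from compound 2 to compound 3. It concerns (the fact that compounds 2 and 3 differ only in the configuration as drawn), not the exchange made here, and it offers no size to carry forward. Within the data shown here, no measured step shows what this exchange does. Since compound 3 sits at a limit, a number for compound 4 could only be read in the direction of stronger inhibition, so that direction is expected, though with little confidence in its size. Among the measured compounds shown here, the sole numerical reference is compound 1 at 1920 nM. The expected change is an at least 12-fold lower number from compound 3 to compound 4 (1.09 log units; beyond the scatter), a rough estimate towards stronger inhibition. For compound 4 the estimated value is 400 nM, with an expected range from 30 nM to 5000 nM.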

Compound 4, half-maximal inhibitory concentration: 4 nM
Beside the measured number, compound 4's estimate is 100-fold (2.00 log units) above it, outside the stated range (below it).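

At this position, on an aromatic carbon ortho to a dimethylamino group, the exchange of nitro for amino in this assay gives an at least 1200-fold lower number from compound 3 to compound 4 (3.09 log units; beyond the scatter), which turns a compound without a readable potency into one with a measured number. As far as these compounds go, compound 3 stands at a limit and not at a number, so the size of this step is only a floor and its true extent stays unknown: the limit of > 5000 nM in this assay, at which 2 of the 4 values shown sit. Within the data shown here, the earlier compounds could not show any of this, since the one step among them cannot be read and touches a different kind of change, leaving this position without a reading until now: the fact that compounds 2 and 3 differ only in the configuration as drawn.

Nothing shown here gives a cause for the large gain in potency on going from nitro to amino. From the compounds shown here alone, it also remains open whether the amino group acts to the same degree with the double bond drawn E rather than Z, and whether a hydroxyl, a methylamino or an acetamide group at this position would hold the potency seen with the amino group.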